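The compounds below may be only part of what the source reports. "The series", "measured", "known", "first", "only" and "open" are said of these compounds alone.

Measured so far, in a functional assay for agonist activity at G protein-coupled receptor 88 (Homo sapiens), read by HTRF and cAMP accumulation; on this read-out lower numbers stand for an effect already at smaller amounts and higher numbers for an effect only at larger amounts of compound:
Compound 1 `N[C@@H](CC1CCCCC1)CN(C(=O)[C@@H]1C[C@H]1c1ccccc1)c1ccc(-c2ccccc2)cc1` — compound 1 gives 1.7 nM
Compound 2 `CO[C@H](C)[C@H](N)CN(C(=O)[C@@H]1C[C@H]1c1ccccc1)c1ccc(-c2ccccc2)cc1` — compound 2 gives 0.68 nM
Compound 3 `CC[C@H](C)[C@H](N)CN(C(=O)[C@@H]1C[C@H]1c1ccccc1F)c1ccc(-c2ccccc2)cc1` — compound 3 gives 650 nM

Compound 3 stands at the highest number of the three in this assay; its gap to compound 1 and its gap to compound 2 are both beyond the scatter, so compound 3 is the weakest of the measured set. Going by the values given here, the single step measured, a 2.5-fold lower number from compound 1 to compound 2 (0.40 log units; beyond the scatter), concerns the amine-bearing chain carbon and not the aryl group on the cyclopropane ring.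

Compound 4 `CC[C@H](C)[C@H](N)CN(C(=O)[C@@H]1C[C@H]1c1ncc(C)s1)c1ccc(-c2ccccc2)cc1` is the next compound, not yet measured. It differs from compound 3 in one place: 5-methyl-1,3-thiazol-2-yl in place of 2-fluorophenyl on a saturated ring carbon. Among the compounds with values here, no measured step touches the group on the saturated ring carbon of the three-membered ring, and compounds 1 and 2 carry an unsubstituted phenyl there rather than either of the groups exchanged here, so there is no precedent in the set for this change. The expectation for compound 4 is therefore set close to compound 3, with a wide range in both directions, amounting to an expected step of a 1.1-fold lower number from compound 3 to compound 4 (0.03 log units; within the scatter). Compound 4 is estimated at 600 nM, between 100 nM and 3500 nM.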

Compound 4, half-maximal effective concentration: 1300 nM
The estimate for compound 4 lay 2.2-fold (0.34 log units) below the measured number; measured number inside the range.
By their numbers in this assay, from the lowest: compound 2; then compound 1; then compounds 3 and 4 (each within the scatter of the next).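

In this assay, going by these compounds alone, a 2.0-fold higher number from compound 3 to compound 4 (0.30 log units; within the scatter) is the first step read at this position, on a saturated ring carbon of the three-membered ring, and it does not separate the two groups. A five-membered aromatic ring with 2 hetero atoms, carrying hydrogen-bond acceptors, thus takes the place of a six-membered aromatic ring of carbon only without a change beyond the scatter. No supporting data bear on this result.

The compounds shown leave open whether an unsubstituted phenyl at this position, paired with the chain of compound 3 and compound 4, would read differently from these two groups. On these data alone, how a pyridin-2-yl group or a thiazole without the methyl group would read here also stays open.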